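Furan-2-yl for phenyl, compound 1 to compound 4

The compounds below may be only part of what the source reports. "The series", "measured", "known", "first", "only" and "open" are said of these compounds alone.

Compound 1 `Nc1nc2c(c(-c3ccccc3)cn2[C@@H]2O[C@H](CO)[C@@H](O)[C@H]2O)c(=O)[nH]1` returns only a limit: in a functional assay on K562 cells (Homo sapiens), read by MTT assay, with a stated time of 72 h (on this read-out lower numbers stand for stronger inhibition and higher numbers for weaker inhibition), compound 1 gives > 20000 nM, a limit rather than a number. Among the three values shown it stands at the limit of > 20000 nM in this assay, at which 2 of the 3 values shown sit. Compound 3 `CNc1ncnc2c1c(-c1cc3ccccc3o1)cn2[C@@H]1O[C@H](CO)[C@@H](O)[C@H]1O` likewise gives only a limit, > 20000 nM, in this assay. Compound 2 `Cc1nc(N)c2c(-c3cc4ccccc4o3)cn([C@@H]3O[C@H](CO)[C@@H](O)[C@H]3O)c2n1`, built on a different core, gives 4990 nM in this assay. Compound 4 `Nc1nc2c(c(-c3ccco3)cn2[C@@H]2O[C@H](CO)[C@@H](O)[C@H]2O)c(=O)[nH]1` differs from compound 1 in one place: furan-2-yl in place of phenyl on an aromatic carbon. Within the data shown here, no measured pair follows this change, so its size is open. With two of three values resting at the limit, the step of a number no higher from compound 1 to compound 4 (the limit leaves the size open) is expected to be small, in either direction, or none beyond the scatter. Compound 4 is therefore estimated at 20000 nM in this assay, within 8000 nM to 50000 nM, most likely again as a limit.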

Compound 4, half-maximal inhibitory concentration: > 20000 nM
Compound 4 ended at the assay's limit (the forecaster's own chance of this, stated with the estimate: 65%); the middle value sits exactly at the limit.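

Compound 1 and compound 4 both rest at a limit, not a number, in this assay, so the change from phenyl to furan-2-yl gives no readable step: the limit of > 20000 nM in this assay, at which 3 of the 4 values shown sit.

As far as these compounds go, whether furan-2-yl and phenyl differ at all on this shared core remains open.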